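Replacing a cyclopentyl amide with an arylethyl amide

The source may hold more compounds than are shown below. What is called first, only, known or untested is meant among the compounds shown, and "the series" means these compounds.

Compound 1 `Cc1ccc(C(=O)N[C@@H](C(=O)N2CCC(c3ccc(Cl)cc3)CC2)C(C)C)cc1`: 25 nM
Compound 2 `Cc1ccccc1C(=O)N[C@@H](C(=O)N1CCC(c2ccc(Cl)cc2)CC1)C(C)C`: 32 nM
Compound 3 `CC(C)[C@@H](NC(=O)C1CCCC1)C(=O)N1CCC(c2ccc(Cl)cc2)CC1`: 70 nM

The three measured compounds share one core and differ only in the group on the carbonyl carbon of the outer amide. In an assay on THP-1 cells for displacement of a labelled ligand from C-C chemokine receptor type 1 (Homo sapiens) (on this read-out higher numbers stand for weaker inhibition and lower numbers for stronger inhibition), compound 3 gives the highest number of the three, with a 2.2-fold higher number from compound 2 to compound 3 (0.34 log units; beyond the scatter) and a 2.8-fold higher number from compound 1 to compound 3 (0.45 log units; beyond the scatter); both steps are modest but beyond the scatter, so compound 3 is the weakest of the measured set. The two aromatic analogues lie within the scatter of each other, as a 1.3-fold higher number from compound 1 to compound 2 (0.11 log units; within the scatter) shows.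

Compound 4 `Cc1ccccc1CCC(=O)N[C@@H](C(=O)N1CCC(c2ccc(Cl)cc2)CC1)C(C)C` carries the change (2-(2-methylphenyl)ethyl in place of cyclopentyl on a carbonyl carbon). Among the measured compounds shown here, the steps from compound 3 to compound 1 and to compound 2 both show that swapping cyclopentyl for a methyl-bearing aromatic ring lowers the number; compound 4 keeps such a ring but also adds the ethyl chain, whose effect no measured pair reports. The estimate therefore leans on the direction of those two steps while widening the range. The expected step is a 1.8-fold lower number from compound 3 to compound 4 (0.24 log units; within the scatter), a modest improvement. For compound 4 the estimated value in this assay is 40 nM, with a range from 12 nM to 130 nM.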

Compound 4, half-maximal inhibitory concentration: 19 nM
For compound 4 the middle estimate is 2.1-fold (0.32 log units) above the measured one, within the range that was stated.
By their numbers in this assay, from the lowest: compounds 4, 1 and 2 (each within the scatter of the next); then compound 3.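

In this assay, the 2-(2-methylphenyl)ethyl group on the carbonyl carbon clearly outperforms cyclopentyl (a 3.7-fold lower number from compound 3 to compound 4 (0.57 log units; beyond the scatter)), so the improvement over compound 3 survives when an ethyl chain separates the aromatic ring from that carbonyl carbon. The chain also brings no detectable loss against the directly attached rings: both comparisons with the earlier aromatic compounds (a 1.7-fold lower number from compound 2 to compound 4 (0.23 log units; within the scatter); a 1.3-fold lower number from compound 1 to compound 4 (0.12 log units; within the scatter)) stay within the scatter, so this position accepts either arrangement, and the larger group can neither be called better nor worse than those two. No independent measurement is available to explain why these groups behave as they do.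

Still open, on these data alone, is how much of the gain over compound 3 comes from the aromatic ring and how much from the chain, a question that a 2-cyclopentylethyl group on the same carbonyl carbon would help to separate. The role of the methyl group also remains unsettled, as do the effects of a plain 2-phenylethyl group, a longer chain ending in the same ring, or an amine or carboxylic acid placed on that ring.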